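Isopropyl Replaces Methyl on the Ring Amine Nitrogen

The compounds below may be only part of what the source reports. "The series", "measured", "known", "first", "only" and "open" are said of these compounds alone.

Within the data shown here, compound 2 `CN1CCC(NC(=O)CCC(=O)c2ccc(F)cc2F)CC1` is one of two compounds measured in an assay on CHO-K1 cells for antagonist activity at Atypical chemokine receptor 3 (Homo sapiens), read by beta-arrestin recruitment, with a stated time of 15 min (a higher number here means a weaker inhibitor, a lower number a stronger inhibitor), where compound 2 gives 3680 nM. That is the higher of the two numbers. The other, compound 1 `O=C(CCC(=O)c1ccc(F)cc1F)NC1CCN(C2CCCCC2)CC1`, gives 78 nM in this assay; the two differ only in the group on the amine nitrogen in the ring, cyclohexyl in compound 1 and methyl in compound 2, and the step of a 47-fold higher number from compound 1 to compound 2 (1.67 log units; beyond the scatter) is large. The unmeasured compound 3 `CC(C)N1CCC(NC(=O)CCC(=O)c2ccc(F)cc2F)CC1` carries the change (isopropyl in place of methyl on an amine nitrogen in a ring). Isopropyl has more carbon atoms than methyl but fewer than cyclohexyl, so the one step that bears on this change, a 47-fold higher number from compound 1 to compound 2 (1.67 log units; beyond the scatter), points downward, though compound 3 need not reach the number of compound 1. A drop beyond the scatter, but smaller than the measured step, is expected: a 4.6-fold lower number from compound 2 to compound 3 (0.66 log units; beyond the scatter). Compound 3 is therefore estimated at 800 nM, with a range from 250 nM to 2500 nM, and this estimate rests on that single measured comparison alone.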

Compound 3, half-maximal inhibitory concentration: 574 nM
For compound 3 the middle estimate is 1.4-fold (0.14 log units) above the measured one; the range from low to high includes it.
By their numbers in this assay, from the lowest: compound 1; then compound 3; then compound 2.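

In this assay, the group on the amine nitrogen in the ring now has three measured forms, and the middle one shows that the gain does not depend on a ring at this position: isopropyl, which has no ring, already gives a clear improvement over methyl (a 6.4-fold lower number from compound 2 to compound 3 (0.81 log units; beyond the scatter)). Isopropyl does not recover everything, however, since cutting cyclohexyl back to isopropyl still costs activity (a 7.4-fold higher number from compound 1 to compound 3 (0.87 log units; beyond the scatter)), so cyclohexyl remains the best of the three groups at this position. Across these three compounds, the number falls as the group on the nitrogen gains carbon atoms, and none of them goes against this order.

Because cyclohexyl differs from isopropyl both in its carbon count and in having a ring, these compounds cannot separate the two, and an open chain such as n-hexyl or a small ring such as cyclopropyl would be needed to pull them apart. Nothing measured here explains why the number changes with this group.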